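Swapping Methyl for Methylamino: Expected Solubility

The source may hold more compounds than are shown below. What is called first, only, known or untested is meant among the compounds shown, and "the series" means these compounds.

Compound 1 `Cc1cc(-c2noc([C@H](C)NC(=O)c3cc(C(F)(F)F)nn3C)n2)ccn1` and compound 2 `COCc1cc(-c2noc([C@H](C)NC(=O)c3cc(C(F)(F)F)nn3C)n2)ccn1` share one core and differ only in a single group on the six-membered aromatic ring. In a physicochemical assay for solubility, measured as kinetic solubility (a higher number here means a more soluble compound, a lower number a less soluble compound), compound 1 gives 179000 nM, and compound 2 gives 200000 nM. Compound 1 thus has the lowest of the two numbers, but the step of a 1.1-fold higher number from compound 1 to compound 2 (0.05 log units; within the scatter) lies within the scatter, so the two compounds cannot be told apart on solubility.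

Compound 3 `CNc1cc(-c2noc([C@H](C)NC(=O)c3cc(C(F)(F)F)nn3C)n2)ccn1` has not yet been measured in this assay. It differs from compound 1 by methylamino in place of methyl on an aromatic carbon. Among the compounds with values here, the only measured step, from compound 1 to compound 2, is the change to methoxymethyl on a saturated chain carbon, and it moved the number very little. Within the data shown here, no measured pair shows a methylamino group entering, so there is no direct precedent for the change to compound 3. Given that the one related step stayed within the scatter, compound 3 is expected to land close to compound 1, with a step of a 1.1-fold higher number from compound 1 to compound 3 (0.03 log units; within the scatter). The estimate for compound 3 is therefore 190000 nM, with a range from 95000 nM to 380000 nM.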

Compound 3, solubility: 143000 nM
For compound 3 the middle estimate is 1.3-fold (0.12 log units) above the measured one, and the stated range covers the measured number.
By their numbers in this assay, from the lowest: compounds 3, 1 and 2 (each within the scatter of the next).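

Within the data shown here, this pair is the first to test a nitrogen-linked group at this place on the ring, next to the ring nitrogen, and in this assay methylamino in place of methyl gives a 1.3-fold lower number from compound 1 to compound 3 (0.10 log units; within the scatter) while methylamino in place of methoxymethyl gives a 1.4-fold lower number from compound 2 to compound 3 (0.15 log units; within the scatter) on the same scale. The position has now carried three groups, methyl, methoxymethyl and methylamino, and all three compounds lie within the scatter of one another, even though methylamino brings a hydrogen-bond donor and a hydrogen-bond acceptor that methyl does not have. No measurement here offers a reason for this flat result.

Going by these compounds, three groups are a small sample, so it remains open whether the number would stay this flat with a carboxylic acid, a longer chain such as butyl, or a ring such as morpholine at the same place. Among these compounds, it is also open whether methylamino in place of methyl would behave the same way on a core other than the one shared by these compounds.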